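Replacing 4-fluorophenyl with 3-nitrophenyl

The source may report more compounds than this note shows. Statements on the series, on what has been measured and on what is new or still open speak of the compounds shown alone.

Compound 1 `COc1ccc(C(=O)N(Cc2ccncc2)Cc2cccc(OCc3ccc(C(F)(F)F)cc3)c2)cc1` gives 14300 nM
Compound 2 `COc1ccc(C(=O)N(Cc2ccncc2)Cc2cccc(OCc3ccc(F)cc3)c2)cc1` gives 22700 nM

In a functional assay on KMS-11 cells (Homo sapiens) for antiproliferative activity, read by CellTiter-Glo, with a stated time of 72 h (a lower number here means a stronger inhibitor, a higher number a weaker inhibitor), compound 2 gives 22700 nM and only compound 1 stands beside it. The step between them is a 1.6-fold higher number from compound 1 to compound 2 (0.20 log units; within the scatter) and so the two values cannot be told apart.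

Compound 3 `COc1ccc(C(=O)N(Cc2ccncc2)Cc2cccc(OCc3cccc([N+](=O)[O-])c3)c2)cc1` keeps the shared core of compound 2 but carries 3-nitrophenyl in place of 4-fluorophenyl on a saturated chain carbon bound to an oxygen on an aromatic ring. The full difference is this: 3-nitrophenyl in place of 4-fluorophenyl on a saturated chain carbon bound to an oxygen on an aromatic ring

Within the data shown here, only one measured step bears on this change. Compound 2 arose from compound 1 by fluoro replacing trifluoromethyl on an aromatic carbon, and that gave a 1.6-fold higher number from compound 1 to compound 2 (0.20 log units; within the scatter) in the same part of the molecule. Among the measured compounds shown here, no measured compound carries 3-nitrophenyl, and a single step is thin evidence. A shift beyond the scatter in this assay is therefore not expected, in either direction. The expected size of the change is a 1.1-fold lower number from compound 2 to compound 3 (0.05 log units; within the scatter) with wide uncertainty. Compound 3 is estimated at 20000 nM with an expected range from 8000 nM to 50000 nM for its measurement.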

Compound 3, half-maximal inhibitory concentration: 19600 nM
The estimate for compound 3 lay 1.0-fold (0.01 log units) above the measured number; low and high end bracket the measured number.
By their numbers in this assay, from the lowest: compounds 1, 3 and 2 (each within the scatter of the next).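

In this assay, 3-nitrophenyl in place of 4-fluorophenyl gives a 1.2-fold lower number from compound 2 to compound 3 (0.06 log units; within the scatter), and 3-nitrophenyl in place of 4-(trifluoromethyl)phenyl gives a 1.4-fold higher number from compound 1 to compound 3 (0.14 log units; within the scatter), so neither exchange can be told apart from repeat-measurement scatter. The earlier pair compared only 4-fluorophenyl with 4-(trifluoromethyl)phenyl, whereas this result adds a different group with a different number in its name, and all three compounds still cannot be separated in this assay. Nothing available here explains why these exchanges leave the values indistinguishable.

What the compounds leave open is whether any change at this position can shift the number beyond the scatter, since three substituted phenyl groups are too few to show that the position tolerates change in general. An amine or a carboxylic acid on this ring, or a longer chain linking the ring to the oxygen, might behave differently, and the compounds shown cannot say either way.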